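The source may hold more compounds than are shown below. What is called first, only, known or untested is meant among the compounds shown, and "the series" means these compounds.

In a functional assay on HeLa cells (Homo sapiens) for antiproliferative activity, read by MTT assay, with a stated time of 48 h (a lower number here means a stronger inhibitor, a higher number a weaker inhibitor), compound 2 `CC(=O)Nc1nccc2ncc(-c3cnn(C)c3)cc12` gives > 50000 nM, which is a limit and not a number. Compound 3 `Cn1cc(-c2cnc3ccnc(NC(=O)c4ccc(F)cc4)c3c2)cn1` gives > 50000 nM, also a limit. Compound 1 `COc1ccc(CNc2ccc3ncc(-c4cnn(C)c4)cc3n2)cc1` gives > 50000 nM, again a limit. Going by the values given here, the series so far shows only (the limit of > 50000 nM in this assay, at which 3 of the 3 values shown sit). Compound 4 `Cn1cc(-c2cnc3ccnc(NCc4ccc(F)cc4)c3c2)cn1` differs from compound 2 by 4-fluorobenzyl in place of acetyl on a nitrogen on an aromatic ring. Among the compounds with values here, the one measured step that bears on this change is a step that the two limits leave unreadable from compound 2 to compound 3, and it offers no size to scale from. No step beyond the scatter is therefore expected in this assay, and the expected step is a number no higher from compound 2 to compound 4 (the limit leaves the size open). The estimated value for compound 4 is 50000 nM, with an expected range of 20000 nM to 100000 nM.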

Compound 4, half-maximal inhibitory concentration: 9200 nM
The estimate for compound 4 lay 5.4-fold (0.74 log units) above the measured number, outside the stated range (below it).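

In this assay, this nitrogen on an aromatic ring can give a readable number: 4-fluorobenzyl in place of acetyl gives an at least 5.4-fold lower number from compound 2 to compound 4 (0.73 log units; beyond the scatter). Compound 3, with a carbonyl on that nitrogen, gives > 50000 nM, which is a limit, so its step from compound 2 cannot be read. A six-membered aromatic ring in the group on this nitrogen therefore does not alone bring a value off the limit, as compound 3 carries one too.

On these data alone, what plain benzyl, a longer chain or a morpholine on this nitrogen would give stays open.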